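The source may report more compounds than this note shows. Statements on the series, on what has been measured and on what is new or still open speak of the compounds shown alone.

Compound 1 `CCCN(C)C(=O)c1cc2c(Cc3ccccc3)n[nH]c2cc1O` carries a propyl chain on its amide-type nitrogen. In a functional assay on A2780 cells (Homo sapiens) for antiproliferative activity, read by resazurin assay, with a stated time of 72 h (on this read-out lower numbers stand for stronger inhibition and higher numbers for weaker inhibition), compound 1 gives > 10000 nM, and this is a limit of the assay rather than a number. Compound 2 `CN(Cc1cccc(Br)c1)C(=O)c1cc2c(Cc3ccccc3)n[nH]c2cc1O` has 3-bromophenyl in place of ethyl on a saturated chain carbon bound to an amide-type nitrogen; in this assay compound 2 gives 7100 nM. That change amounts to an at least 1.4-fold lower number from compound 1 to compound 2 (0.14 log units; that floor lies within the scatter), a floor that sits within the usual scatter, so no real gain can be claimed from it. Compound 3 `CN(Cc1cccc(C(F)(F)F)c1)C(=O)c1cc2c(Cc3ccccc3)n[nH]c2cc1O` carries 3-(trifluoromethyl)phenyl on a saturated chain carbon bound to an amide-type nitrogen; for compound 3 this assay reports "not determined" (no result reported).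

Compound 4 `CN(Cc1ccc(F)cc1)C(=O)c1cc2c(Cc3ccccc3)n[nH]c2cc1O` differs from compound 1 by 4-fluorophenyl in place of ethyl on a saturated chain carbon bound to an amide-type nitrogen. Among the measured compounds shown here, the only measured step that bears on this change is the one to compound 2, where a benzylic arm replaced the plain chain and the number moved only slightly. Because compound 1 sits at the limit of > 10000 nM in this assay, at which 1 of the 3 values shown sits, the size of any real change from it cannot be read. For compound 4 the expected step is therefore small, an at least 1.2-fold lower number from compound 1 to compound 4 (0.09 log units; that floor lies within the scatter), toward somewhat stronger inhibition. Compound 4 is estimated to give about 8000 nM in this assay, with a range of 3000 nM to 20000 nM.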

Compound 4, half-maximal inhibitory concentration: 4100 nM
For compound 4 the middle estimate is 2.0-fold (0.29 log units) above the measured one, within the range that was stated.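

In this assay, among the compounds shown here, the step from a propyl chain to 4-fluorobenzyl gives an at least 2.4-fold lower number from compound 1 to compound 4 (0.38 log units; beyond the scatter), which makes it the first step on a saturated chain carbon bound to an amide-type nitrogen that clears the usual scatter; the earlier step to compound 2 had only a floor inside it. Going by these compounds, the true size of this step stays unknown, and the printed figure is only a minimum, because the value for compound 1 is a limit of the assay and not a number: the limit of > 10000 nM in this assay, at which 1 of the 4 values shown sits. Exchanging one ring-bearing arm for the other gives a 1.7-fold lower number from compound 2 to compound 4 (0.24 log units; within the scatter), which lies within the scatter, so these data do not separate 4-fluorophenyl from 3-bromophenyl on this arm.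

On these data alone, it remains open whether the aromatic ring itself matters or whether a longer plain chain, such as hexyl, would do as well as 4-fluorobenzyl. As far as these compounds go, it is also open how this arm would respond to a plain benzyl with no halogen on its ring, or to a ring carrying an amine or a carboxylic acid.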